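Replacing an Aryl Group with a Carboxy Chain

The source may report more compounds than this note shows. Statements on the series, on what has been measured and on what is new or still open speak of the compounds shown alone.

In a functional assay on Caco-2 cells (Homo sapiens) for antiproliferative activity, read by MTT assay, with a stated time of 48 h (a lower number here means a stronger inhibitor, a higher number a weaker inhibitor), compound 1 (`CCn1c(C(=O)NCCCN(C)C)ccc1C(CC)(CC)c1ccc(OCCC(O)(CC)CC)c(C)c1`) gives 490 nM. Compound 2 (`C#CCCOC(=O)c1ccc(C(CC)(CC)c2ccc(OCCC(O)(CC)CC)c(C)c2)n1CC`) reads > 50000 nM, which is a limit of the assay and not a number. Compound 3 (`CCOc1ccc(NC(=O)c2ccc(C(CC)(CC)c3ccc(OCCC(O)(CC)CC)c(C)c3)n2CC)cc1`) reads > 50000 nM, again only a limit. Compound 3 therefore sits at the limit of > 50000 nM in this assay, at which 2 of the 3 values shown sit.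

Compound 4 (`CCC(C)C(NC(=O)c1ccc(C(CC)(CC)c2ccc(OCCC(O)(CC)CC)c(C)c2)n1CC)C(=O)O`) carries 1-carboxy-2-methylbutyl in place of 4-ethoxyphenyl on an amide-type nitrogen.

Among the measured compounds shown here, two measured steps bear on this change, and both are large: an at least 100-fold higher number from compound 1 to compound 2 (2.00 log units; beyond the scatter), and an at least 100-fold higher number from compound 1 to compound 3 (2.00 log units; beyond the scatter). Each removes the 3-(dimethylamino)propyl group, which compound 4 also lacks. The remaining step, a step that the two limits leave unreadable from compound 2 to compound 3, cannot be sized, so it offers no guide. Resting on an at least 100-fold higher number from compound 1 to compound 3 (2.00 log units; beyond the scatter), only a small shift toward a lower number is expected, and it may not be readable: an at least 1.6-fold lower number from compound 3 to compound 4 (0.22 log units; that floor lies within the scatter).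

For compound 4, the estimated value is 30000 nM, with an expected range from 5000 nM to 50000 nM.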

Compound 4, half-maximal inhibitory concentration: 20000 nM
Compound 4: middle estimate off by 1.5-fold (0.18 log units), on the high side, and the stated range covers the measured number.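

Placing 1-carboxy-2-methylbutyl on the amide-type nitrogen in place of 4-ethoxyphenyl gives an at least 2.5-fold lower number from compound 3 to compound 4 (0.39 log units; beyond the scatter), and putting (1-carboxy-2-methylbutyl)amino on the carbonyl carbon in place of (but-3-yn-1-yl)oxy gives an at least 2.5-fold lower number from compound 2 to compound 4 (0.39 log units; beyond the scatter). Compound 3 itself remains a limit of the assay and not a number: the limit of > 50000 nM in this assay, at which 2 of the 4 values shown sit. Compound 4 is the only compound shown without 3-(dimethylamino)propyl that gives a number in this assay, yet the compound carrying that group keeps a clear lead: a 41-fold higher number from compound 1 to compound 4 (1.61 log units; beyond the scatter).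

The compounds shown do not separate the contribution of the carboxy group from that of the branched carbon chain in 1-carboxy-2-methylbutyl. Also open, as far as these compounds go, is how a primary amine, or a longer chain ending in a carboxylic acid, would read on this nitrogen.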